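Swapping the aryl substituent on a shared thiazole-free core

The source may hold more compounds than are shown below. What is called first, only, known or untested is meant among the compounds shown, and "the series" means these compounds.

Three compounds share one core. Compound 1 `Cc1cccc(-c2nc(C)c(COc3ccc4c(c3)OCC4CC(=O)O)s2)c1` and compound 2 `Cc1nc(-c2cccc(Cl)c2)sc1COc1ccc2c(c1)OCC2CC(=O)O` were both run in a functional assay on CHO cells for agonist activity at Free fatty acid receptor 1 (Homo sapiens), read by FLIPR and calcium flux (a higher number here means that more compound is needed for the effect, a lower number that less compound is needed), and compound 3 `Cc1nc(-c2ccccc2F)sc1COc1ccc2c(c1)OCC2CC(=O)O` has no reported result there, its entry reading "not determined" (no result reported). Compound 1 gives 119 nM, and compound 2 gives 138 nM. Compound 2 thus holds the higher of the two numbers, but its nearest neighbour is compound 1, and the step of a 1.2-fold higher number from compound 1 to compound 2 (0.06 log units; within the scatter) lies within the scatter, so the two values cannot be ordered.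

Compound 4 `Cc1nc(-c2ccc(C(F)(F)F)cc2)sc1COc1ccc2c(c1)OCC2CC(=O)O` is the next entry, differing from compound 2 by 4-(trifluoromethyl)phenyl in place of 3-chlorophenyl on an aromatic carbon. For the measured compounds named here, the only measured step that touches the same place is the step of a 1.2-fold higher number from compound 1 to compound 2 (0.06 log units; within the scatter), which exchanged one small group on the aryl ring and left the number essentially unchanged. Going by the values given here, the change to compound 4 is larger, since both the group and its position on the aryl ring move, so the single measured step is only a loose guide. On that basis the expected step of a 1.2-fold higher number from compound 2 to compound 4 (0.09 log units; within the scatter) is small, in no firm direction, and probably within the scatter. For compound 4 the estimate in this assay is 170 nM, with a range from 60 nM to 500 nM.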

Compound 4, half-maximal effective concentration: 96.7 nM
The estimate for compound 4 lay 1.8-fold (0.25 log units) above the measured number; low and high end bracket the measured number.
By their numbers in this assay, from the lowest: compounds 4, 1 and 2 (each within the scatter of the next).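

In this assay the step of a 1.4-fold lower number from compound 2 to compound 4 (0.15 log units; within the scatter) and the step of a 1.2-fold lower number from compound 1 to compound 4 (0.09 log units; within the scatter) both lie within the scatter, so compound 1, compound 2 and compound 4 cannot be ordered. The earlier pair had shown this only for an exchange of one small group on the aryl ring, whereas here 4-(trifluoromethyl)phenyl, with 10 heavy atoms, takes the place of 3-chlorophenyl, with 7, on the same aromatic carbon of the five-membered ring, and the group and its position on the aryl ring both differ, yet the values still cannot be told apart. Nothing available on these compounds offers an explanation for this result.

Steps to compound 3 cannot be read, as it has no reported result, so these compounds say nothing about a group placed on the aryl ring at the position it carries there. As far as these compounds go, it also remains open whether the values would stay within the scatter with an amine or a carboxylic acid on the aryl ring, or with a longer chain in place of the aryl ring altogether.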